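The source may report more compounds than this note shows. Statements on the series, on what has been measured and on what is new or still open speak of the compounds shown alone.

Working notes on the series.

Compound 3, `Cc1cc(NC(=O)CC(C)(C)C)nn1Cc1cc(Cl)ccc1OCc1ccccc1`, stands at the top of what is readable here. In a physicochemical assay for lipophilicity, at pH 7.4 (a lower number here means a more polar compound, a higher number a more lipophilic compound), compound 3 gives > 3.7, which is a limit of the assay and not a number. Compound 1, `CNC(=O)c1cc(C)n(Cc2cc(Cl)ccc2OCc2ccccc2)n1`, gives > 3.7 in this assay, again a limit. Compound 2, `Cc1cc(C(=O)NCc2ccccn2)nn1Cc1cc(Cl)ccc1OCc1ccccc1`, gives > 3.7, also a limit. The three measured steps, a step that the two limits leave unreadable from compound 1 to compound 2, a step that the two limits leave unreadable from compound 1 to compound 3 and a step that the two limits leave unreadable from compound 2 to compound 3, are therefore all unreadable in size, since (the limit of > 3.7 in this assay, at which 3 of the 3 values shown sit).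

The next compound, compound 4, `Cc1cc(NC(=O)c2c(F)cccc2F)nn1Cc1cc(Cl)ccc1OCc1ccccc1`, differs from compound 3 in one place: 2,6-difluorophenyl in place of neopentyl on a carbonyl carbon. Going by the values given here, no measured step bears on this change in a readable way; the only information is that the whole measured set sits at the limit.

Compound 4 is accordingly expected to sit at the limit as well, the step that the limit leaves unreadable from compound 3 to compound 4 being an expectation without any readable precedent. The estimate for compound 4 in this assay is 4.2, within 3.7 to 4.8.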

Compound 4, distribution coefficient: > 3.7
Compound 4: no number, only a limit; the forecaster's own chance of this, stated with the estimate: 85%; the middle value is on the limit's open side.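

In this assay compound 4 gives > 3.7 and this is a limit of the assay, not a number. Going by these compounds alone, no step from compound 1, compound 2 or compound 3 to compound 4 can be read. The order of these four compounds in this assay remains open, with all of them at one limit: the limit of > 3.7 in this assay, at which 4 of the 4 values shown sit.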